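Removing the methoxy from compound 3: working notes

The source may report more compounds than this note shows. Statements on the series, on what has been measured and on what is new or still open speak of the compounds shown alone.

Measured in a functional assay on MOLT-4 cells (Homo sapiens) for antiproliferative activity, read by cell counting, with a stated time of 2 days; on this read-out higher numbers stand for weaker inhibition and lower numbers for stronger inhibition:
- compound 1 `COc1cc(C(=O)c2sc(N(C)C)nc2N)cc(OC)c1OC`: "not determined" (no result reported)
- compound 2 `CCN(CC)c1nc(N)c(C(=O)c2cc(OC)c(OC)c(OC)c2)s1`: "not determined" (no result reported)
- compound 3 `COc1ccc(C(=O)c2sc(N3CCCC3)nc2N)cc1`: > 200000 nM (a limit)

Compound 1 and compound 2 have no reported result, so neither offers a number for comparison. Compound 3 is the only one of the set with a reported result, and that result is a limit, not a number: > 200000 nM in this assay. The evidence so far amounts to the limit of > 200000 nM in this assay, at which 1 of the 3 values shown sits.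

The next compound is compound 4 `Nc1nc(N2CCCC2)sc1C(=O)c1ccccc1`. It keeps the shared core of compound 3 and carries hydrogen in place of methoxy on an aromatic carbon, para to a large group (hydrogen in place of methoxy on an aromatic carbon).

Going by the values given here, no pair of measured compounds gives a step size for this series, so the expectation rests on a single limit and carries wide uncertainty. No step beyond the usual scatter is expected in either direction, and a clear gain in inhibition would be a surprise. The expected size of the change is a number no higher from compound 3 to compound 4 (the limit leaves the size open). It is expected that this assay will quite likely report only a limit again. In this assay the estimate for compound 4 is 200000 nM, with an expected range of 60000 nM to 400000 nM.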

Compound 4, half-maximal inhibitory concentration: > 200000 nM
Compound 4 gave a limit, no number (the forecaster's own chance of this, stated with the estimate: 85%); the middle value lies on the limit itself.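

Compound 3 and compound 4 each give only a limit, not a number, in this assay, so no step between them can be read: the limit of > 200000 nM in this assay, at which 2 of the 4 values shown sit.

The compounds shown leave open whether hydrogen in place of methoxy on this aromatic carbon changes inhibition at all, and what value either compound would give as a number.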